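Fluorophenyl placement within the guanidine series

This account rests on a few compounds, and the source may have more. Where it says the series, first, only, none or still open, it means among the compounds named here.

Three measured compounds share one core and differ only in the aryl group held on a saturated chain carbon. In a functional assay on cardiac atrium for agonist activity at histamine H2 receptor (Cavia porcellus) (on this read-out lower numbers stand for lower potency and higher numbers for higher potency (the scale is a negative logarithm)), compound 1 `N=C(NCCCc1c[nH]cn1)NCCC(c1ccc(F)cc1)c1ccccn1` gives 8.01. Compound 2 `N=C(NCCCc1c[nH]cn1)NCCC(c1ccc(Cl)cc1)c1ccccn1` gives 7.84. Compound 3 `N=C(NCCCc1c[nH]cn1)NCCC(c1cccc(F)c1)c1ccccn1` gives 7.88. All three numbers lie within the scatter of one another: the step is a number 0.13 log units lower from compound 1 to compound 3 (within the scatter), and likewise a number 0.04 log units higher from compound 2 to compound 3 (within the scatter), so compound 3 cannot be set apart from either of the other two on this read-out.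

Compound 4 `N=C(NCCCc1c[nH]cn1)NCCC(c1ccccn1)c1ccccc1F` has not yet been measured. It differs from compound 3 by 2-fluorophenyl in place of 3-fluorophenyl on a saturated chain carbon bound to an aromatic carbon and a saturated chain carbon. Going by the values given here, two measured steps bear on such an aryl change: a number 0.13 log units lower from compound 1 to compound 3 (within the scatter), which also moved the fluorine to a different ring carbon, and a number 0.17 log units lower from compound 1 to compound 2 (within the scatter), which exchanged the halogen. Neither went beyond the scatter. The expected step is therefore a number 0.03 log units lower from compound 3 to compound 4 (within the scatter), that is, no change beyond the scatter in either direction. For compound 4 the estimate in this assay is 7.85, with a range from 7.4 to 8.3.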

Compound 4, negative logarithm of the half-maximal effective concentration: 7.46
Estimate against measurement, compound 4: 0.39 log units above; the range from low to high includes it.
By their numbers in this assay, from the lowest: compound 4; then compounds 2, 3 and 1 (each within the scatter of the next).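

The aryl group on this saturated chain carbon is not as tolerant as the first three compounds suggested: in this assay, 2-fluorophenyl in place of 3-fluorophenyl gives a number 0.42 log units lower from compound 3 to compound 4 (beyond the scatter), and the same group gives a number 0.55 log units lower from compound 1 to compound 4 (beyond the scatter) when it replaces 4-fluorophenyl. Since the two compounds in each of these pairs have the same atoms joined differently, the fluorine's place on the ring alone separates compound 4 from compounds 1 and 3, whereas 3-fluorophenyl and 4-fluorophenyl could not be told apart; the step with a change of halogen as well, a number 0.38 log units lower from compound 2 to compound 4 (beyond the scatter), leaves compound 4 lowest of the four, with its steps to all the others beyond the scatter. Nothing at hand accounts for this loss of potency.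

On these data alone, whether the loss belongs to fluorine itself or would follow other groups on the same ring carbon remains open, and 2-chlorophenyl or 2-methylphenyl would test this. Also open, as far as these compounds go, is how 2-fluorophenyl would read when combined with a second halogen, as in a difluorophenyl or chlorofluorophenyl group, and whether a further substituent would add to the loss or offset it.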